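This account rests on a few compounds, and the source may have more. Where it says the series, first, only, none or still open, it means among the compounds named here.

Compound 1 `CN(C)CCNc1cc2c(cn1)cc(NC(=O)c1cc3ccccc3s1)c(=O)n2C`, compound 2 `COc1cccc(C(=O)Nc2cc3cnc(NCCN(C)C)cc3n(C)c2=O)c1` and compound 3 `CN(C)CCNc1cc2c(cn1)cc(NC(=O)/C=C/c1ccccc1)c(=O)n2C` share one core and differ only in the group attached to a carbonyl carbon. In a functional assay on MCF7 cells (Homo sapiens) for antiproliferative activity, read by MTT assay, with a stated time of 48 h (on this read-out lower numbers stand for stronger inhibition and higher numbers for weaker inhibition), compound 1 gives 12000 nM, compound 2 gives 43300 nM and compound 3 gives 27400 nM, so compound 2 shows the highest number of the three. Compound 4 `CN(C)CCNc1cc2c(cn1)cc(NC(=O)c1ccc(Cl)cc1)c(=O)n2C` has not been measured; it carries 4-chlorophenyl in place of 3-methoxyphenyl on a carbonyl carbon. Within the data shown here, no measured step introduces a 4-chlorophenyl, so the nearest guides are the two steps that leave or reach the 3-methoxyphenyl: a 3.6-fold higher number from compound 1 to compound 2 (0.56 log units; beyond the scatter) and a 1.6-fold lower number from compound 2 to compound 3 (0.20 log units; within the scatter). A modest move toward a lower number is therefore expected. For compound 4 the expected step is a 1.7-fold lower number from compound 2 to compound 4 (0.24 log units; within the scatter). The estimate for compound 4 in this assay is 25000 nM, between 8000 nM and 70000 nM.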

Compound 4, half-maximal inhibitory concentration: 3090 nM
Beside the measured number, compound 4's estimate is 8.1-fold (0.91 log units) above it, and the stated range ends above it.
By their numbers in this assay, from the lowest: compound 4; then compound 1; then compounds 3 and 2 (each within the scatter of the next).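

In this assay, among these compounds, the group on the carbonyl carbon matters more than the earlier compounds showed: 4-chlorophenyl gives a 14-fold lower number from compound 2 to compound 4 (1.15 log units; beyond the scatter), a larger step than any seen among them. It also gives an 8.9-fold lower number from compound 3 to compound 4 (0.95 log units; beyond the scatter) and a 3.9-fold lower number from compound 1 to compound 4 (0.59 log units; beyond the scatter), which makes compound 4 the strongest of the four. No evidence is available to explain this gain. Going by these compounds, how a plain phenyl, a 3-chlorophenyl or a 4-methoxyphenyl would compare remains open, so the gain cannot yet be assigned to the chlorine or to its place on the ring.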